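This account rests on a few compounds, and the source may have more. Where it says the series, first, only, none or still open, it means among the compounds named here.

Among the compounds with values here, in a functional assay on SGC-7901 cells (Homo sapiens) for antiproliferative activity, read by MTT assay, with a stated time of 72 h (a lower number here means a stronger inhibitor, a higher number a weaker inhibitor), compound 1 `COc1cc(-n2cnc3ccc(-c4ccc(C)cc4F)cc32)cc(OC)c1OC` gives 5650 nM and compound 2 `COc1cc(-n2cnc3ccc(-c4cccc(Cl)c4)cc32)cc(OC)c1OC` gives 1490 nM, so compound 2 holds the lower of the two numbers so far. Compound 3 `COc1cc(-n2cnc3ccc(-c4cccc(O)c4)cc32)cc(OC)c1OC` carries hydroxy in place of chloro on an aromatic carbon, meta to a large group: hydroxy in place of chloro on an aromatic carbon. Within the data shown here, the only measured step, a 3.8-fold lower number from compound 1 to compound 2 (0.58 log units; beyond the scatter), is modest and exchanges different groups, so it gives no direction for this change. Little shift beyond the scatter is therefore expected, and the estimated step is a 1.1-fold lower number from compound 2 to compound 3 (0.06 log units; within the scatter). Compound 3 is expected at 1300 nM, with an estimated range of 350 nM to 5000 nM.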

Compound 3, half-maximal inhibitory concentration: 53 nM
Beside the measured number, compound 3's estimate is 25-fold (1.39 log units) above it; the whole stated range lies above it.
By their numbers in this assay, from the lowest: compound 3; then compound 2; then compound 1.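

In this assay, hydroxy in place of chloro on this aromatic carbon, meta to a large group, gives a 28-fold lower number from compound 2 to compound 3 (1.45 log units; beyond the scatter), so exchanging one heavy atom here moves the number much further than the earlier modest step did. With 3-hydroxyphenyl in place of 2-fluoro-4-methylphenyl, the change reaches a 110-fold lower number from compound 1 to compound 3 (2.03 log units; beyond the scatter). Nothing given here accounts for this shift.

On these data alone, it remains open whether a methoxy or an amine at this place would keep a number as low as that of compound 3. As far as these compounds go, whether hydroxy would do the same elsewhere on this ring also remains open.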